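Swapping 4-methoxycyclohexyl for morpholin-4-yl on compound 1

The source may report more compounds than this note shows. Statements on the series, on what has been measured and on what is new or still open speak of the compounds shown alone.

- compound 1 `COc1cccc(OC)c1C(=O)Nc1c[nH]nc1C(=O)N[C@H]1CC[C@H](OC)CC1` measured at 31000 nM
- compound 2 `CCc1ccccc1C(=O)Nc1c[nH]nc1C(=O)N[C@H]1CC[C@H](OC)CC1` measured at 3400 nM

In an ADME assay on MRC5 cells (Homo sapiens) for inhibition, with a stated time of 72 h (on this read-out lower numbers stand for an effect already at smaller amounts and higher numbers for an effect only at larger amounts of compound), compound 1 stands higher of the two, at 31000 nM. Its gap to compound 2 lies beyond the usual scatter. Compound 3 `COc1cccc(OC)c1C(=O)Nc1c[nH]nc1C(=O)NN1CCOCC1` has morpholin-4-yl in place of 4-methoxycyclohexyl on an amide-type nitrogen. Within the data shown here, no measured pair shows this change, so the expectation rests on compound 1 at 31000 nM alone, and no step beyond the scatter is expected. The estimated step is a 1.3-fold higher number from compound 1 to compound 3 (0.11 log units; within the scatter) and could go either way. For compound 3 the estimate is 40000 nM with 12000 nM to 100000 nM as its expected range.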

Compound 3, half-maximal effective concentration: > 50000 nM
Compound 3: a limit, no number (the forecaster's own chance of this, stated with the estimate: 40%); middle value at least 1.2-fold (0.09 log units) from the limit.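

At this place, on an amide-type nitrogen, morpholin-4-yl in place of 4-methoxycyclohexyl gives an at least 1.6-fold higher number from compound 1 to compound 3 (0.20 log units; that floor lies within the scatter). In this assay compound 3 gives > 50000 nM, which is a limit and not a number. The 4-methoxycyclohexyl group of compound 1 still gave a readable value here, while morpholin-4-yl reaches the limit, so only a floor for the step is known: the limit of > 50000 nM in this assay, at which 1 of the 3 values shown sits.

The compounds shown leave open whether a plain cyclohexyl or an open hexyl chain in this place would give a readable number. They also leave open how the same swap would read on compound 2.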